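Replacing the nitro group of compound 2 with amino

The compounds below may be only part of what the source reports. "The series", "measured", "known", "first", "only" and "open" are said of these compounds alone.

In a functional assay on MGC-803 cells (Homo sapiens) for inhibition, read by CCK-8 assay, with a stated time of 48 h (a lower number here means a stronger inhibitor, a higher number a weaker inhibitor), compound 1 (`COc1cc(N(Cc2ccc(Cl)cc2)C(=O)CSC(=S)N2CCN(C(=O)OC(C)(C)C)CC2)cc(OC)c1OC`) gives 12900 nM, and compound 2 (`COc1ccc(CN(C(=O)CSC(=S)N2CCN(C(=O)OC(C)(C)C)CC2)c2cc(OC)c(OC)c(OC)c2)cc1[N+](=O)[O-]`) gives 880 nM, the lower of the two numbers. Compound 3 (`COc1ccc(CN(C(=O)CSC(=S)N2CCN(C(=O)OC(C)(C)C)CC2)c2cc(OC)c(OC)c(OC)c2)cc1N`) keeps the rest of compound 2 but carries amino in place of nitro on an aromatic carbon, ortho to a methoxy group: amino in place of nitro on an aromatic carbon. Among the compounds with values here, only one measured step bears on this change: a 15-fold lower number from compound 1 to compound 2 (1.17 log units; beyond the scatter), a large step that came with 4-methoxy-3-nitrophenyl in place of 4-chlorophenyl. Within the data shown here, it shows that this part of the structure can shift the number strongly in this assay, but no measured compound carries amino, so the direction remains open. No step beyond the scatter is therefore expected, and the estimated change is a 1.3-fold lower number from compound 2 to compound 3 (0.10 log units; within the scatter). For compound 3, the estimated value is 700 nM, with an expected range of 150 nM to 3200 nM.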

Compound 3, half-maximal inhibitory concentration: 184 nM
Estimate against measurement, compound 3: 3.8-fold (0.58 log units) above; the measured number falls inside the stated range.
By their numbers in this assay, from the lowest: compound 3; then compound 2; then compound 1.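

In this assay, the position ortho to a methoxy group proves sensitive to the group it carries, beyond the earlier replacement of the whole 4-chlorophenyl part: amino in place of nitro on this aromatic carbon gives a 4.8-fold lower number from compound 2 to compound 3 (0.68 log units; beyond the scatter). The change removes nitro, with 3 heavy atoms and 0 hydrogen-bond donors, and brings in amino, with 1 heavy atom and 1 hydrogen-bond donor; measured against the 4-chlorophenyl compound, 3-amino-4-methoxyphenyl gives a 70-fold lower number from compound 1 to compound 3 (1.85 log units; beyond the scatter). Nothing measured here accounts for the step at this position.

The compounds shown leave open how a hydroxyl, an acetamido or a dimethylamino group on the same aromatic carbon would compare with amino. They also leave open whether amino would give a similar step with an ethoxy group in place of the methoxy group.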